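Acetyl in place of dimethylamino on a pyrazole-linked biaryl

The compounds below may be only part of what the source reports. "The series", "measured", "known", "first", "only" and "open" are said of these compounds alone.

Compound 1 `COc1cc(C)cc(-c2c(-c3ccnc(-c4ccc(N(C)C)cc4)c3)cnn2CC#N)c1` stands second highest of the three numbers in a functional assay on SK-OV-3 cells (Homo sapiens) for cytotoxicity, read by sulforhodamine B assay, with a stated time of 48 h, tested at 1 uM (on this read-out higher numbers stand for a weaker effect at the one concentration tested and lower numbers for a stronger effect), where compound 1 gives 36%. Its nearest neighbour, compound 2 `Cc1cc(O)cc(-c2nn(CC#N)cc2-c2ccnc(-c3ccc(Oc4ccccc4)cc3)c2)c1`, gives 63% in this assay, a number higher than compound 1 beyond the scatter. Furthest away lies compound 3 `COc1cc(C)cc(-c2nn(CC#N)cc2-c2ccc(-c3cccc(C(C)=O)c3)nc2)c1`, which gives -4% in this assay, well below compound 1. Compound 4 `COc1cc(C)cc(-c2c(-c3ccnc(-c4ccc(C(C)=O)cc4)c3)cnn2CC#N)c1` has not yet been measured; it differs from compound 1 by acetyl in place of dimethylamino on an aromatic carbon. Among the compounds with values here, no step between measured compounds covers this change, so the size of the move is uncertain. Compound 4 is expected to reach 22%, with a range from -10% to 55%, a step of a number 14 percentage points lower from compound 1 to compound 4 (beyond the scatter) that is expected to run toward lower numbers, partly because compound 3, which also carries an acetyl, gives -4%.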

Compound 4, a percentage reported as activity, at one concentration (the size of the read-out at that concentration, not a potency): 19%
The estimate for compound 4 lay 3 percentage points above the measured number; measured number inside the range.
By their numbers in this assay, from the lowest: compound 3; then compound 4; then compound 1; then compound 2.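

In this assay, within the data shown here, the change from 4-(dimethylamino)phenyl to 4-acetylphenyl gives a number 17 percentage points lower from compound 1 to compound 4 (beyond the scatter) and is the first single change that can be read directly, with a stronger effect at the one concentration tested. The two groups have the same counts of heavy atoms and hydrogen-bond acceptors, so the step comes with no change in those counts. No measured evidence accounts for the shift.

Going by these compounds, whether a carboxylic acid, a primary amine or a longer ketone chain in this place would move the number further remains open. Potency also remains open, since one concentration does not give it.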